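The source may hold more compounds than are shown below. What is called first, only, known or untested is meant among the compounds shown, and "the series" means these compounds.

Measured so far in an assay on isolated protein for inhibition of serine/threonine-protein kinase D2 (Homo sapiens), read by mobility shift assay, tested at 30 uM; a higher number here means more inhibition at the concentration tested (going by the name of the read-out), a lower number less inhibition:
- compound 1 `Cc1cc2nc(N)nc(N)c2c(=O)[nH]1`: compound 1 gives 8%
- compound 2 `Cc1cc2nc(-c3ccccc3)nc(N)c2c(=O)[nH]1`: compound 2 gives 5%

Both numbers sit low in this assay. For the measured compounds named here, the one measured step, a number 3 percentage points lower from compound 1 to compound 2 (within the scatter), came with phenyl in place of amino on an aromatic carbon, and it did not move the read-out beyond the scatter. Compound 2 therefore stands as the lower of the two numbers, but its gap to compound 1 is within the scatter, so no order between them can be claimed.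

Compound 3 `Cc1nc(N)c2c(=O)[nH]c(C)cc2n1` is not yet measured. Against compound 2 the change is methyl in place of phenyl on an aromatic carbon. Going by the values given here, the only step that bears on it is the one from compound 1 to compound 2, which swapped the group at the same place and stayed within the scatter; there is no measured step that puts methyl there. On that basis no movement beyond the scatter is expected from a number 1 percentage points higher from compound 2 to compound 3 (within the scatter). The estimate for compound 3 in this assay is 6%, expected to fall between -4% and 16%.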

Compound 3, a percentage reported as inhibition, at one concentration (the size of the read-out at that concentration, not a potency): 6%
The estimate for compound 3 equals the measured number at the digits printed, within the range that was stated.
By their numbers in this assay, from the lowest: compounds 2, 3 and 1 (each within the scatter of the next).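

In this assay, the aromatic carbon between two ring nitrogen atoms now has a third group on record: methyl in place of phenyl gives a number 1 percentage points higher from compound 2 to compound 3 (within the scatter) and methyl in place of amino gives a number 2 percentage points lower from compound 1 to compound 3 (within the scatter). Cutting the substituent from a six-membered aromatic ring of carbon only to a single carbon therefore does not separate the two compounds beyond the scatter, and amino, phenyl and methyl cannot be placed in any order at this position. No data are available that would explain these results.

As far as these compounds go, whether a carboxylic acid, a dimethylamino group or a longer chain such as butyl at this carbon would give a number beyond the scatter of these three remains open. Also open, from the compounds shown here alone, is what replacing the amino group or the ring methyl shared by compound 1, compound 2 and compound 3 would do, since every step here concerns the one position.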